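Moving the fluorine on compound 2: compound 3

A few compounds are considered here, and "the series" means these few. Any claim that something is new, unique, unknown or untested is made for them only; others in the source may bear on it.

Measured so far:
compound 1 `COc1cc(-n2ncnc2-c2cccc([N+](=O)[O-])c2)cc(OC)c1OC` gives > 10000 nM
compound 2 `COc1cc(-n2ncnc2-c2ccc(F)cc2)cc(OC)c1OC` gives > 10000 nM

In a functional assay on HeLa cells (Homo sapiens) for antiproliferative activity, read by MTT assay, with a stated time of 72 h (on this read-out lower numbers stand for stronger inhibition and higher numbers for weaker inhibition), compound 1 gives > 10000 nM, which is a limit of the assay rather than a number. In this assay compound 2 likewise gives > 10000 nM, again a limit. Both sit at the limit of > 10000 nM in this assay, at which 2 of the 2 values shown sit, so compound 2 stands level with compound 1 and nothing separates them. Compound 3 `COc1cc(-n2ncnc2-c2cccc(F)c2)cc(OC)c1OC` differs from compound 2 by 3-fluorophenyl in place of 4-fluorophenyl on an aromatic carbon. No measured step of this kind is shown, so in this assay no step beyond the scatter is expected. Compound 3 is expected to give 15000 nM, between 5000 nM and 50000 nM. The expected step is a step that the limit leaves unreadable from compound 2 to compound 3.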

Compound 3, half-maximal inhibitory concentration: > 10000 nM
Compound 3 gave a limit, no number (the forecaster's own chance of this, stated with the estimate: 75%); the middle value does not contradict the limit.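

In this assay, among these compounds, compound 1, compound 2 and compound 3 all give only a limit, not a number, so no step between them can be read: the limit of > 10000 nM in this assay, at which 3 of the 3 values shown sit. On these data alone, whether swapping 4-fluorophenyl for 3-fluorophenyl, or nitro for fluoro, changes activity stays open.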